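From 4-Chlorophenyl to 4-Methoxyphenyl

The source may hold more compounds than are shown below. What is called first, only, known or untested is meant among the compounds shown, and "the series" means these compounds.

In a functional assay on MDA-MB-231 cells (Homo sapiens) for antiproliferative activity, read by MTT assay, with a stated time of 72 h (a lower number here means a stronger inhibitor, a higher number a weaker inhibitor), compound 1 `NC1=NC2(CCSCC2)N(OCCCOc2ccc(Cl)c(Cl)c2)C(N)=N1` gives 10 nM and compound 2 `NC1=NC2(CCSCC2)N(OCCCOc2cccc(Cl)c2Cl)C(N)=N1` gives 1 nM. Compound 3 `NC1=NC2(CCSCC2)N(OCCCOc2ccc(Cl)cc2)C(N)=N1`, at 350 nM, is the weakest inhibitor of the three. Compound 4 `COc1ccc(OCCCON2C(N)=NC(N)=NC23CCSCC3)cc1` has methoxy in place of chloro on an aromatic carbon. Within the data shown here, no measured step makes this swap. The closest evidence is a 35-fold higher number from compound 1 to compound 3 (1.54 log units; beyond the scatter) and a 350-fold higher number from compound 2 to compound 3 (2.54 log units; beyond the scatter). Both steps are large and both remove chloro, so the substituents on this phenyl group clearly matter, yet neither shows what methoxy does. A small upward step, probably within the scatter, is therefore expected, with wide uncertainty: a 1.7-fold higher number from compound 3 to compound 4 (0.23 log units; within the scatter). For compound 4 the estimated value is 600 nM, with an expected range of 150 nM to 2500 nM.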

Compound 4, half-maximal inhibitory concentration: 350 nM
For compound 4 the middle estimate is 1.7-fold (0.23 log units) above the measured one; the measured number falls inside the stated range.
By their numbers in this assay, from the lowest: compound 2; then compound 1; then compounds 3 and 4 (each within the scatter of the next).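

On this aromatic carbon, methoxy and chloro cannot be told apart in this cell test (no change at the digits printed from compound 3 to compound 4 (within the scatter)), although methoxy brings an oxygen and one more heavy atom. Compound 4 also sits as far from the two dichlorophenyl compounds as compound 3 does (a 350-fold higher number from compound 2 to compound 4 (2.54 log units; beyond the scatter); a 35-fold higher number from compound 1 to compound 4 (1.54 log units; beyond the scatter)). Nothing available offers a reason for this match.

Going by these compounds, whether an amine or a carboxylic acid on this carbon would give a similar number stays open. So does whether methoxy could replace a chloro in compound 1 or compound 2 with as little effect.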